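Aryl group in place of cycloheptyl on the ring nitrogen

A few compounds are considered here, and "the series" means these few. Any claim that something is new, unique, unknown or untested is made for them only; others in the source may bear on it.

Compound 1 `Nc1scc(CN2CCN(c3ccc(Cl)cc3Cl)CC2)c1C(=O)c1ccc(Cl)cc1` gives -74% in a functional assay on CHO cells with adenosine receptor A1 (Homo sapiens) as the target, read by cAMP accumulation and immunoassay, with a stated time of 6 min, tested at 10 uM; on this read-out lower numbers stand for a stronger effect and higher numbers for a weaker effect at the one concentration tested.
Compound 2 `Nc1scc(CN2CCN(C3CCCCCC3)CC2)c1C(=O)c1ccc(Cl)cc1` gives -25% in this assay.

Compound 2 holds the highest of the two numbers; its nearest neighbour is compound 1, and the step of a number 49 percentage points higher from compound 1 to compound 2 (beyond the scatter) separates them, with cycloheptyl in place of 2,4-dichlorophenyl on an amine nitrogen in a ring. Compound 3 `Nc1scc(CN2CCN(c3cccc(F)c3)CC2)c1C(=O)c1ccc(Cl)cc1` has not yet been measured in this assay. It differs from compound 2 in one place: 3-fluorophenyl in place of cycloheptyl on an amine nitrogen in a ring. Going by the values given here, the only measured step that bears on this change is a number 49 percentage points higher from compound 1 to compound 2 (beyond the scatter), which ran in the opposite direction and was large, an aryl group giving way to cycloheptyl. Here an aryl group returns, though 3-fluorophenyl is not 2,4-dichlorophenyl, so how much of that step is recovered remains uncertain. On that basis a step of a number 30 percentage points lower from compound 2 to compound 3 (beyond the scatter) is expected, downward and beyond the scatter. Compound 3 is therefore estimated at -55% in this assay, with a range from -80% to -25%.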

Compound 3, a percentage reported as activity, at one concentration (the size of the read-out at that concentration, not a potency): -82%
Estimate against measurement, compound 3: 27 percentage points above; measured number below the stated range.
By their numbers in this assay, from the lowest: compounds 3 and 1 (each within the scatter of the next); then compound 2.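

In this assay the change to 3-fluorophenyl on the amine nitrogen gives a number 57 percentage points lower from compound 2 to compound 3 (beyond the scatter) and so shows that the large difference from cycloheptyl is not particular to 2,4-dichlorophenyl. The comparison of the two aryl groups gives a number 8 percentage points lower from compound 1 to compound 3 (within the scatter) in the same assay, so a single fluorine and two chlorines on the phenyl ring, at different ring places, cannot be told apart on this read-out; among the three compounds, the two aryl compounds share the lower numbers and cycloheptyl stands alone at the higher one. No measurement shown here accounts for this difference between the aryl groups and cycloheptyl.

The compounds shown leave open whether an aromatic ring itself matters at this nitrogen or whether cycloheptyl is a poor case among non-aromatic groups, a question that cyclohexyl or benzyl could help to settle. They also leave open whether the halogens contribute at all, which an unsubstituted phenyl group or a pyridyl ring at the same nitrogen would begin to show.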